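Methoxy in Place of Dimethylamino on the Side Chain

The source may hold more compounds than are shown below. What is called first, only, known or untested is meant among the compounds shown, and "the series" means these compounds.

Compound 1 `Cn1ncc(Cl)c1-c1cc(C(=O)N[C@@H]2CN[C@H](CC(O)CO)C[C@H]2c2ccc(F)c(F)c2)oc1Cl` gives 3.31 nM in an assay for inhibition of RAC-alpha serine/threonine-protein kinase (Homo sapiens), read by HTRF, with a stated time of 1 h (on this read-out higher numbers stand for weaker inhibition and lower numbers for stronger inhibition), and compound 2 `Cn1ncc(Cl)c1-c1cc(C(=O)N[C@@H]2CN[C@H](CCCO)C[C@H]2c2ccc(Cl)c(Cl)c2)oc1Cl` gives 2.56 nM. Compound 3 `CN(C)CC[C@@H]1C[C@@H](c2ccc(Cl)c(Cl)c2)[C@H](NC(=O)c2cc(-c3c(Cl)cnn3C)c(Cl)o2)CN1` gives 3.4 nM, a number that sits within the scatter of both compound 1 and compound 2. Among the compounds with values here, the only single-place step among them, a 1.3-fold higher number from compound 2 to compound 3 (0.12 log units; within the scatter), shows that the tail of the side chain has so far been exchanged without a shift beyond the scatter. Compound 4 `COCC[C@@H]1C[C@@H](c2ccc(Cl)c(Cl)c2)[C@H](NC(=O)c2cc(-c3c(Cl)cnn3C)c(Cl)o2)CN1` carries methoxy in place of dimethylamino on a saturated chain carbon, two bonds along the chain from a saturated ring carbon. Within the data shown here, only that one step bears on this change, and it was small, so the number for compound 4 in this assay is expected to stay close to that of compound 3, with the estimated step being a 1.3-fold higher number from compound 3 to compound 4 (0.12 log units; within the scatter). Compound 4 is therefore estimated at 4.5 nM, within a range from 1.5 nM to 14 nM.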

Compound 4, half-maximal inhibitory concentration: 7.01 nM
Compound 4: middle estimate off by 1.6-fold (0.19 log units), on the low side, within the range that was stated.
By their numbers in this assay, from the lowest: compounds 2, 1 and 3 (each within the scatter of the next); then compound 4.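

In this assay, within the data shown here, methoxy on the side chain gives a 2.1-fold higher number from compound 3 to compound 4 (0.31 log units; beyond the scatter) and, set against hydroxymethyl, a 2.7-fold higher number from compound 2 to compound 4 (0.44 log units; beyond the scatter) and these are the first steps at this place to lie beyond the scatter. The end of the chain therefore does register in this read-out, though only modestly, since dimethylamino and hydroxymethyl had stayed within the scatter of each other. Nothing at hand accounts for the shift. The compounds shown leave open how a primary amine, a carboxylic acid or a longer chain would read at this place.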